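Bromo on the aromatic ring of compound 2

The source may report more compounds than this note shows. Statements on the series, on what has been measured and on what is new or still open speak of the compounds shown alone.

In a functional assay on HCT-116 cells (Homo sapiens) for inhibition, read by colorimetric assay, with a stated time of 3 days (on this read-out lower numbers stand for stronger inhibition and higher numbers for weaker inhibition), compound 2 `O=C(CCCCCCNC(=O)C(O)(O)C(F)(F)F)Nc1ccccc1` gives 9140 nM and compound 3 `O=C(CCCCCCNC(=O)C(O)(O)C(F)(F)F)Nc1ccc(-c2ccccc2)cc1` gives 4730 nM in the same read-out. The two stand together within the scatter (a 1.9-fold lower number from compound 2 to compound 3 (0.29 log units; within the scatter)). Compound 1 `O=C(CCCCCCNC(=O)c1cc(=O)c(O)co1)Nc1ccccc1` gives > 100000 nM as a limit of the assay and not a number. For the measured compounds named here, compound 2 therefore has only one numeric neighbour.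

Compound 4 `O=C(CCCCCCNC(=O)C(O)(O)C(F)(F)F)Nc1cccc(Br)c1` differs from compound 2 by bromo in place of hydrogen on an aromatic carbon. Two measured steps are at hand. The one of the same kind is phenyl in place of hydrogen on an aromatic carbon (a 1.9-fold lower number from compound 2 to compound 3 (0.29 log units; within the scatter)), and it stayed within the scatter. The other (an at least 10-fold lower number from compound 1 to compound 2 (1.03 log units; beyond the scatter)) was large, but it exchanges a group on a carbonyl carbon, and compound 4 keeps that group as in compound 2, so it sets no size here.

In this assay no step beyond the scatter is expected in either direction, given compound 3 at 4730 nM on the same kind of replacement. The expected step is small (a 1.3-fold lower number from compound 2 to compound 4 (0.12 log units; within the scatter)). For compound 4 the estimated value is 7000 nM with an expected range from 3000 nM to 16000 nM in this read-out.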

Compound 4, half-maximal inhibitory concentration: 3060 nM
The estimate for compound 4 lay 2.3-fold (0.36 log units) above the measured number, within the range that was stated.
By their numbers in this assay, from the lowest: compounds 4, 3 and 2 (each within the scatter of the next, the first and the last beyond it). At a limit, above all of these: compound 1.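

In this assay, bromo in place of hydrogen on an aromatic carbon, meta to a large group, gives a 3.0-fold lower number from compound 2 to compound 4 (0.48 log units; beyond the scatter), the only replacement on this ring shown here whose step lies beyond the scatter. The other replacement on this ring, phenyl in place of hydrogen, gives a 1.9-fold lower number from compound 2 to compound 3 (0.29 log units; within the scatter), so the series now holds one case in which a substituent on this ring moves the number past the scatter, a modest step that rests on compound 4 alone. No measurement at hand bears on the cause of this step.

On these data alone, it remains open whether the step belongs to bromo itself or to its place on the ring, and whether bromo on another carbon of the ring, or chloro, a methoxy group or an amine meta to a large group, would give a step of the same size. Also open, as far as these compounds go, is whether bromo would keep this step on a longer chain in the shared core.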